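Aryl-triazole lactone series: from compound 2 to compound 4

The source may hold more compounds than are shown below. What is called first, only, known or untested is meant among the compounds shown, and "the series" means these compounds.

Measured compounds:
compound 1, `O=C1O[C@H]([C@@H](O)Cn2cc(-c3cc(C(F)(F)F)cc(C(F)(F)F)c3)nn2)C(OCc2ccccc2)=C1OCc1ccccc1` — in a functional assay on SW-620 cells (Homo sapiens) for antiproliferative activity, read by MTT assay, with a stated time of 72 h (on this read-out lower numbers stand for stronger inhibition and higher numbers for weaker inhibition), compound 1 gives 49200 nM
compound 2, `O=C1O[C@H]([C@@H](O)Cn2cc(-c3cccc(O)c3)nn2)C(OCc2ccccc2)=C1OCc1ccccc1` — in this assay compound 2 gives only a limit, > 100000 nM
compound 3, `COc1ccc(-c2cn(C/C=C3\OC(=O)C(OCc4ccccc4)=C3OCc3ccccc3)nn2)cc1` — in this assay compound 3 gives only a limit, > 100000 nM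

Compound 2 therefore stands at the top of what this assay can report: its value is a limit of the assay, not a number, and it shares that position with the limit of > 100000 nM in this assay, at which 2 of the 3 values shown sit. Among the compounds with values here, compound 1 is the only member with a measured number, and that number is itself weak. Within the data shown here, no two measured compounds differ in a single place, so no measured step is available to calibrate the change considered here.

Compound 4 is `COc1ccc(-c2cn(C[C@H](O)[C@H]3OC(=O)C(OCc4ccccc4)=C3OCc3ccccc3)nn2)cc1`. Against compound 2 the change is 4-methoxyphenyl in place of 3-hydroxyphenyl on an aromatic carbon. The rest of the molecule, including the hydroxy-bearing linker and the shared core, is kept.

Among the measured compounds shown here, with compound 2 at the limit and the only measured number, compound 1, also weak, the step from compound 2 to compound 4 is expected to be none beyond the scatter, a number no higher from compound 2 to compound 4 (the limit leaves the size open). Compound 4 is estimated at 100000 nM, with a range from 40000 nM to 300000 nM, most probably again reported only as a limit.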

Compound 4, half-maximal inhibitory concentration: 58200 nM
Beside the measured number, compound 4's estimate is 1.7-fold (0.24 log units) above it, within the range that was stated.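

In this assay, 4-methoxyphenyl in place of 3-hydroxyphenyl on the aromatic carbon of the five-membered ring with 3 nitrogen gives an at least 1.7-fold lower number from compound 2 to compound 4 (0.23 log units; that floor lies within the scatter), so this change cannot yet be read as a real gain. Within the data shown here, it does show that this position, with the hydroxy-bearing linker and the shared core kept, can carry a group other than the one in compound 1 and still return a measured number: compound 1 gives 49200 nM and compound 4 gives 58200 nM, both weak on this read-out. The true size of the step stays open because the value of compound 2 is a limit and not a number: the limit of > 100000 nM in this assay, at which 2 of the 4 values shown sit.

The compounds shown leave open whether the result follows the exchange of hydroxy for methoxy or the different place of the group on the phenyl ring, and 3-methoxyphenyl or 4-hydroxyphenyl at this position would separate the two. Also open, on these data alone, is whether a phenyl ring bearing an amine or a carboxylic acid would bring a number clearly stronger than those of compound 1 and compound 4.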